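Removing the chloro from compound 1: an expected small shift

The compounds below may be only part of what the source reports. "The series", "measured", "known", "first", "only" and "open" are said of these compounds alone.

Compound 1, `O=C(Nc1nnc(-c2cccc(O)c2O)s1)c1ccc(Cl)cc1`, is one of three thiadiazole amides tested in a functional assay on A549 cells (Homo sapiens) for cytotoxicity, read by MTT assay, with a stated time of 72 h (a higher number here means a weaker inhibitor, a lower number a stronger inhibitor), where compound 1 gives 9500 nM. This is the lowest number of the three, but compound 2, `Cc1ccc(C(=O)Nc2nnc(-c3ccc(O)c(O)c3)s2)cc1`, sits within the usual scatter of it, giving 11800 nM, while compound 3, `O=C(COc1ccccc1)Nc1nnc(-c2ccc(O)c(O)c2)s1`, stands furthest away at 21200 nM. Within the data shown here, the only single-point step among the measured compounds, a 1.8-fold higher number from compound 2 to compound 3 (0.25 log units; within the scatter), concerns the amide side of the shared core and not the ring that carries the hydroxy groups.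

Compound 4, `O=C(Nc1nnc(-c2cccc(O)c2O)s1)c1ccccc1`, differs from compound 1 only by hydrogen in place of chloro on an aromatic carbon. Among the measured compounds shown here, no measured step touches this position, so there is nothing to say that the change should move the number either way. The expectation is therefore a step of a 1.3-fold higher number from compound 1 to compound 4 (0.10 log units; within the scatter), not beyond the scatter, and compound 4 is estimated at 12000 nM, with a likely range from 6000 nM to 25000 nM.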

Compound 4, half-maximal inhibitory concentration: 12300 nM
Beside the measured number, compound 4's estimate is 1.0-fold (0.01 log units) below it, within the range that was stated.
By their numbers in this assay, from the lowest: compounds 1, 2, 4 and 3 (each within the scatter of the next, the first and the last beyond it).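

In this assay, going from 4-chlorophenyl to phenyl gives a 1.3-fold higher number from compound 1 to compound 4 (0.11 log units; within the scatter) and so stays within the scatter. Among these compounds, this is the first measured change at this place on the amide side of the shared core, and it shows that, in this pair, the number does not depend on having the chloro there. No available evidence gives a reason for a step of this size.

A single exchange of chloro for hydrogen says little about the position as a whole, and a larger or differently charged group, such as an amine, a carboxylic acid or a longer chain, could give a different result in the same place. As far as these compounds go, it also remains open whether this exchange would give a similar step with the hydroxy groups arranged as in compound 2.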